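The source may report more compounds than this note shows. Statements on the series, on what has been measured and on what is new or still open speak of the compounds shown alone.

Measured compounds in this series:
compound 1, `CCS(=O)(=O)Nc1ccc(NC(=O)c2ccc(C#N)cc2)cc1OC`: 66400 nM
compound 2, `COc1cc(NC(=O)c2ccc(C#N)cc2)ccc1NS(=O)(=O)C(F)(F)F`: > 250000 nM
compound 3, `CCS(=O)(=O)Nc1ccc(NC(=O)c2ccc(Cl)cc2)cc1Cl`: > 250000 nM

All values come from an ADME assay on RAW264.7 cells (Mus musculus) for cytotoxicity, read by MTT assay, with a stated time of 48 h; on this read-out higher numbers stand for weaker inhibition and lower numbers for stronger inhibition. Compound 1 gives 66400 nM. For compound 2 the value is a limit of this assay, > 250000 nM. For compound 3 the value is likewise a limit, > 250000 nM. The change from compound 1 to compound 2, (trifluoromethyl in place of ethyl on a sulfonyl sulfur), gives an at least 3.7-fold higher number from compound 1 to compound 2 (0.57 log units; beyond the scatter), with compound 2 sitting at the limit of > 250000 nM in this assay, at which 2 of the 3 values shown sit.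

Compound 4, `O=C(Nc1ccc(NS(=O)(=O)C(F)(F)F)c(Cl)c1)c1ccc(Cl)cc1`, is not yet measured. It stands to compound 3 as compound 2 stands to compound 1: trifluoromethyl in place of ethyl on a sulfonyl sulfur, the same change at the same place, the two place descriptions being identical word for word. The difference between the core of compound 3 and the core of compound 1 is not broken down here. Compound 3 already sits at the limit of > 250000 nM in this assay, at which 2 of the 3 values shown sit, so for compound 4 only a limit is expected as well. The expected step for compound 4 is a step that the limit leaves unreadable from compound 3 to compound 4. The estimate for compound 4 is 320000 nM, within 150000 nM to 700000 nM.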

Compound 4, half-maximal inhibitory concentration: 47200 nM
For compound 4 the middle estimate is 6.8-fold (0.83 log units) above the measured one; the measured number lies below the stated range.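

In this assay, trifluoromethyl in place of ethyl on a sulfonyl sulfur gives an at least 5.2-fold lower number from compound 3 to compound 4 (0.72 log units; beyond the scatter) and thus does not carry over from one core to the other with a single direction or size: the same change on two cores in this assay, an at least 3.7-fold higher number (0.57 log units; beyond the scatter) from compound 1 to compound 2 and an at least 5.2-fold lower number (0.72 log units; beyond the scatter) from compound 3 to compound 4, at least 19-fold (1.29 log units) apart, beyond the scatter of two such steps

Each of the two steps has one end at a limit, so their exact sizes cannot be read, and only the direction of each is established: the limit of > 250000 nM in this assay, at which 2 of the 4 values shown sit.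

The results give no cause for the reversal, and two matched pairs set no rule for any other core in this series.

On these data alone, the difference between the core of compound 1 and the core of compound 3 is not broken down, so it remains open which part of it reverses the step. Also open, as far as these compounds go, is how a longer chain such as propyl, or a group carrying an amine, on the sulfonyl sulfur would compare with ethyl and trifluoromethyl on each core.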